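Chloro in place of trifluoromethyl: compound 1 to compound 3

A few compounds are considered here, and "the series" means these few. Any claim that something is new, unique, unknown or untested is made for them only; others in the source may bear on it.

Compound 1 `CC(=O)N[C@H]1/C(=N/NC(=O)Nc2ccc(C(F)(F)F)cc2)O[C@H](CO)[C@@H](O)[C@@H]1O` is one of two measured members of the series. In an assay on isolated protein (Homo sapiens) for inhibition of HEXA/HEXB (Bos taurus), using a Dixon plot (a higher number here means a weaker inhibitor, a lower number a stronger inhibitor), compound 1 gives 125 nM. Compound 2 `CC(=O)N[C@H]1/C(=N/NC(=O)Nc2ccc3ccccc3c2)O[C@H](CO)[C@@H](O)[C@@H]1O`, the other measured member, gives 47 nM in this assay. On these two numbers compound 1 stands highest; its nearest neighbour is compound 2, whose number lies lower by a gap beyond the usual scatter, so compound 2 is the stronger inhibitor of the pair.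

The next compound, compound 3 `CC(=O)N[C@H]1/C(=N/NC(=O)Nc2ccc(Cl)cc2)O[C@H](CO)[C@@H](O)[C@@H]1O`, is built from compound 1 by one change: chloro in place of trifluoromethyl on an aromatic carbon. For the measured compounds named here, no pair of measured compounds differs in a single place, so there is no measured step on which to rest a direction for this change. Going by the values given here, the only comparison available, compound 1 against compound 2, alters a different part of the molecule and does not speak to a chloro for trifluoromethyl exchange.

The step from compound 1 to compound 3 in this assay is therefore expected to be small, a 1.1-fold lower number from compound 1 to compound 3 (0.06 log units; within the scatter), in no particular direction and not clearly beyond the scatter. For compound 3 the estimate in this assay is 110 nM, with an expected range from 40 nM to 320 nM.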

Compound 3, inhibition constant: 170 nM
The estimate for compound 3 lay 1.5-fold (0.19 log units) below the measured number; the range from low to high includes it.
By their numbers in this assay, from the lowest: compound 2; then compounds 1 and 3 (each within the scatter of the next).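

In this assay, chloro in place of trifluoromethyl on an aromatic carbon, para to a large group, gives a 1.4-fold higher number from compound 1 to compound 3 (0.13 log units; within the scatter), the first single-place step measured in this series. Four heavy atoms leave and one enters, yet the two compounds cannot be told apart on these numbers, so at this position the binding read-out does not depend on trifluoromethyl as such. No measurement at hand bears on why the exchange leaves the number within the scatter.

Trifluoromethyl and chloro are the only two groups compared at this position, so it stays open whether an amine, a carboxylic acid, a methoxy group or plain hydrogen on the same aromatic carbon would also stay within the scatter of compound 1 or would move the number clearly in either direction. For the compounds shown here, it also stays open whether the tolerance seen here holds on other aromatic carbons of the same ring, since every step so far concerns this one place.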